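Chloro in place of fluoro on compound 3

This account rests on a few compounds, and the source may have more. Where it says the series, first, only, none or still open, it means among the compounds named here.

Values in a functional assay on RAW264.7 cells (Mus musculus) for inhibition, read by microscopy, with a stated time of 4 days, in the presence of a further agent that is not named here; a lower number here means a stronger inhibitor, a higher number a weaker inhibitor:
- compound 1 `O=C(Nc1ccc(Br)cc1F)c1cc(F)ccc1O` gives 1860 nM
- compound 2 `O=C(Nc1ccc(Br)cc1F)c1cc(Cl)ccc1O` gives 2140 nM
- compound 3 `O=C(Nc1ccc(I)cc1F)c1cc(F)ccc1O` gives 1570 nM
- compound 4 `O=C(Nc1ccc(I)cc1F)c1cc(Cl)ccc1O` has not yet been measured

In this assay the three measured compounds form a tight group, and compound 3 , at 1570 nM, lies within the scatter of both compound 1 and compound 2. The next step leads to compound 4 and is a single exchange: chloro in place of fluoro on an aromatic carbon. This is chloro in place of fluoro on an aromatic carbon, para to a hydroxy group.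

The same exchange has already been measured on the bromo counterpart, as a 1.2-fold higher number from compound 1 to compound 2 (0.06 log units; within the scatter). The exchange of bromo for iodo, seen as a 1.2-fold lower number from compound 1 to compound 3 (0.07 log units; within the scatter), was equally small. Both steps stay within the scatter, so no step beyond the scatter is expected here. The expected step is a 1.1-fold higher number from compound 3 to compound 4 (0.06 log units; within the scatter). For compound 4 the estimated value is 1800 nM, with an expected range from 1150 nM to 2800 nM.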

Compound 4, half-maximal inhibitory concentration: 1840 nM
Compound 4: middle estimate off by 1.0-fold (0.01 log units), on the low side; measured number inside the range.
By their numbers in this assay, from the lowest: compounds 3, 4, 1 and 2 (each within the scatter of the next).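

On a second core in this assay, chloro in place of fluoro, para to a hydroxy group, again gives only a small step, a 1.2-fold higher number from compound 3 to compound 4 (0.07 log units; within the scatter), and the size of the exchange holds across the bromo and iodo compounds: the same change on two cores in this assay, a 1.2-fold higher number (0.06 log units; within the scatter) from compound 1 to compound 2 and a 1.2-fold higher number (0.07 log units; within the scatter) from compound 3 to compound 4, 1.0-fold (0.01 log units) apart, within the scatter of two such steps

Iodo in place of bromo can now also be read twice, since the chloro compounds give a 1.2-fold lower number from compound 2 to compound 4 (0.07 log units; within the scatter), which matches the step on the fluoro compounds: the same change on two cores in this assay, a 1.2-fold lower number (0.07 log units; within the scatter) from compound 1 to compound 3 and a 1.2-fold lower number (0.07 log units; within the scatter) from compound 2 to compound 4, 1.0-fold (0.01 log units) apart, within the scatter of two such steps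

Across these four compounds, each exchange stays within the scatter whichever halogen sits at the other place.

From the compounds shown here alone, only fluoro and chloro have been compared at this position, so it remains open whether an amine, a methoxy group or a carboxylic acid there would move the number beyond the scatter. Going by these compounds, the hydroxy group and the amide are the same in all four compounds, so what each contributes also remains open.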